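The source may hold more compounds than are shown below. What is called first, only, known or untested is meant among the compounds shown, and "the series" means these compounds.

Compounds measured in a functional assay on COLO 205 cells (Homo sapiens) for antiproliferative activity; on this read-out higher numbers stand for weaker inhibition of growth and lower numbers for stronger inhibition of growth:
- compound 1 `COCCCCCCCCCCCCCCC/C=C1/CC(CO)(COC(=O)C(C)(C)C)OC1=O`: 0.178 ug/mL
- compound 2 `COC(=O)CCCCCCCCCCCCCC/C=C1\CC(CO)(COC(=O)C(C)(C)C)OC1=O`: 3.86 ug/mL
- compound 3 `CCCCCOCCCCCCC/C=C1\CC(CO)(COC(=O)C(C)(C)C)OC1=O`: 0.491 ug/mL

Of these three, compound 2 carries the highest number, at 3.86 ug/mL. Compound 3 lies nearest to it and compound 1 furthest from it.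

Compound 4 `CC(C)(C)C(=O)OCCCCCCCCCCCCCCC/C=C1\CC(CO)(COC(=O)C(C)(C)C)OC1=O` has not yet been measured in this assay. It departs from compound 2 in a single place: (((tert-butyl)carbonyl)oxy)methyl in place of methoxycarbonyl on a saturated chain carbon, ten or more bonds along the chain from a double-bonded chain carbon. The same difference can be read as 3-(methoxycarbonyl)propyl to 4-(((tert-butyl)carbonyl)oxy)butyl.

Among the compounds with values here, only one measured step bears on this change, and only loosely: a 7.9-fold lower number from compound 2 to compound 3 (0.90 log units; beyond the scatter). That modest step, beyond the scatter, put pentyloxy in place of 7-(methoxycarbonyl)heptyl, so it replaced much more of the chain than the present change does. Within the data shown here, it shows that the number for compound 2 can move when its chain is altered, but no measured step isolates the loss of methoxycarbonyl alone. A smaller shift is therefore expected, leaning towards a lower number and perhaps not leaving the scatter.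

The estimated step is a 1.8-fold lower number from compound 2 to compound 4 (0.24 log units; within the scatter). For compound 4 the expected value is 2.2 ug/mL, with an estimated range from 0.6 ug/mL to 8 ug/mL.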

Compound 4, concentration for 50% growth inhibition: 0.597 ug/mL
Beside the measured number, compound 4's estimate is 3.7-fold (0.57 log units) above it; the whole stated range lies above it.
By their numbers in this assay, from the lowest: compound 1; then compounds 3 and 4 (each within the scatter of the next); then compound 2.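

In this assay, the end of the chain matters on its own: with the chain otherwise kept, (((tert-butyl)carbonyl)oxy)methyl in place of methoxycarbonyl on a saturated chain carbon gives a 6.5-fold lower number from compound 2 to compound 4 (0.81 log units; beyond the scatter). The earlier step, a 7.9-fold lower number from compound 2 to compound 3 (0.90 log units; beyond the scatter), replaced much more of the chain, so it could not show whether the terminal methoxycarbonyl itself counted for anything, and the new step shows that a change confined to this far end is enough to go beyond the scatter. No measurement of any property of these groups accompanies the result, so the data offer no reason for the shift.

The compounds shown leave open whether the lower number follows from the (((tert-butyl)carbonyl)oxy)methyl group in particular or from replacing methoxycarbonyl by almost any other end group, since a carboxylic acid, a free hydroxymethyl or an amine at the same chain end does not appear among them. They also leave open whether this end group would give a step of the same size on a shorter chain, or on the other geometry of the double bond, which appears here only in compound 1 with a different chain end.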